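The compounds below may be only part of what the source reports. "The series", "measured", "known", "first", "only" and "open" are said of these compounds alone.

Compound 1 `C1=C(CCN2CCN(c3cccc4c3OCCO4)CC2)c2ccccc2CCC1`: 380 nM
Compound 2 `c1ccc2c(c1)CC(CCCN1CCN(c3cccc4c3OCCO4)CC1)C2`: 1860 nM

In an assay on isolated protein for binding affinity to 5-hydroxytryptamine receptor 1B (Rattus norvegicus) (a higher number here means a weaker inhibitor, a lower number a stronger inhibitor), compound 2 gives 1860 nM, the higher of the two numbers here, while compound 1 gives 380 nM, and that gap lies beyond the usual scatter. Compound 3 `Clc1cccc2c1CC2CCCN1CCN(c2cccc3c2OCCO3)CC1` has not yet been measured. It differs from compound 2 in one place: a group of 9 heavy atoms (8 carbon, 1 chlorine; one four-membered non-aromatic ring of carbon only, one six-membered aromatic ring of carbon only) in place of a group of 9 heavy atoms (9 carbon; one five-membered non-aromatic ring of carbon only, one six-membered aromatic ring of carbon only), on a saturated chain carbon, three bonds along the chain from an amine nitrogen in a ring. Among the measured compounds shown here, no measured pair shows this exchange, so nothing here tells which way it will go; the step of a 1.2-fold lower number from compound 2 to compound 3 (0.09 log units; within the scatter) is expected to be small and may stay within the scatter. Compound 3 is therefore estimated at 1500 nM, with a range from 450 nM to 5000 nM.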

Compound 3, inhibition constant: 1100 nM
For compound 3 the middle estimate is 1.4-fold (0.13 log units) above the measured one; measured number inside the range.
By their numbers in this assay, from the lowest: compound 1; then compounds 3 and 2 (each within the scatter of the next).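

In this assay, replacing 2,3-dihydro-1H-inden-2-yl with the chlorine-bearing group containing a four-membered ring, on the saturated chain carbon, gives a 1.7-fold lower number from compound 2 to compound 3 (0.23 log units; within the scatter) and so leaves the two compounds indistinguishable. At this position, then, a different ring size plus a chlorine, with the same count of heavy atoms, produces no readable change. As far as these compounds go, whether an amine or a carboxylic acid at this chain carbon would give a step beyond the scatter stays open, as does the separate contribution of the chlorine. Nothing measured here offers a reason for this result.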